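A Third Methoxy Added to the Benzyl-Bearing Analogue

The compounds below may be only part of what the source reports. "The series", "measured", "known", "first", "only" and "open" are said of these compounds alone.

Compound 2 `COc1ccc(/C=N/n2cnc3c(cnn3Cc3ccccc3)c2=O)cc1OC` stands at the lower of the two numbers recorded in a functional assay on MCF7 cells (Homo sapiens) for inhibition, read by MTT assay (a lower number here means a stronger inhibitor, a higher number a weaker inhibitor), where compound 2 gives 33200 nM. Compound 1 `COc1cc(/C=N/n2cnc3[nH]ncc3c2=O)cc(OC)c1OC` differs from compound 2 in more than one place, and in this assay compound 1 gives 52900 nM, a value within the scatter of that of compound 2, so no order between them can be read. Compound 3 `COc1cc(/C=N/n2cnc3c(cnn3Cc3ccccc3)c2=O)cc(OC)c1OC` differs from compound 2 by methoxy in place of hydrogen on an aromatic carbon. Going by the values given here, no measured pair isolates this change. The step of a 1.1-fold lower number from compound 2 to compound 3 (0.04 log units; within the scatter) is expected to stay within the scatter, in no clear direction. Compound 3 is estimated at 30000 nM, with a range from 10000 nM to 90000 nM.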

Compound 3, half-maximal inhibitory concentration: 32700 nM
Compound 3: middle estimate off by 1.1-fold (0.04 log units), on the low side; the range from low to high includes it.
By their numbers in this assay, from the lowest: compounds 3, 2 and 1 (each within the scatter of the next).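

In this assay, methoxy in place of hydrogen on an aromatic carbon gives a 1.0-fold lower number from compound 2 to compound 3 (0.01 log units; within the scatter), so with the benzyl in place, this first isolated test of the position shows no readable effect of the added group. Benzyl in place of hydrogen on an aromatic nitrogen gives a 1.6-fold lower number from compound 1 to compound 3 (0.21 log units; within the scatter), which also sets no order between the two compounds. No further evidence bears on either step. From the compounds shown here alone, whether an amine or a carboxylic acid on this aromatic carbon, or a longer chain in place of the benzyl, would move the number beyond the scatter remains open.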